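A few compounds are considered here, and "the series" means these few. Any claim that something is new, unique, unknown or untested is made for them only; others in the source may bear on it.

Compound 1 `O=C1/C(=C/c2cccc(Cl)c2)Cc2ccccc21` and compound 2 `O=C1/C(=C/c2cccc(Br)c2)Cc2ccccc21` share one core, and in a functional assay on CCRF-CEM cells (Homo sapiens) for inhibition (a lower number here means a stronger inhibitor, a higher number a weaker inhibitor), compound 1 gives 31800 nM while compound 2 gives 32400 nM. The change between them is bromo in place of chloro on an aromatic carbon, and the step of a 1.0-fold higher number from compound 1 to compound 2 (0.01 log units; within the scatter) shows the two numbers cannot be told apart. Compound 3 `O=C1/C(=C/c2cccc(Cl)c2)CCCc2ccccc21` has a different core; the difference between the two cores is not broken down here. In this assay compound 3 gives 9440 nM, the lowest of the three numbers, and its gap to compound 1 and to compound 2 lies beyond the scatter. Compound 4 `O=C1/C(=C/c2cccc(Br)c2)CCCc2ccccc21` carries the same change on the core of compound 3: bromo in place of chloro on an aromatic carbon. Since this change is made at the same place as before, and since it left the number essentially unchanged from compound 1 to compound 2 in the step of a 1.0-fold higher number from compound 1 to compound 2 (0.01 log units; within the scatter), a similarly flat step is expected from compound 3 to compound 4, namely a 1.0-fold higher number from compound 3 to compound 4 (0.01 log units; within the scatter). For compound 4 the expected value in this assay is therefore 9600 nM, with a likely range from 5500 nM to 17000 nM.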

Compound 4, half-maximal inhibitory concentration: 8900 nM
Beside the measured number, compound 4's estimate is 1.1-fold (0.03 log units) above it, within the range that was stated.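

In this assay the new step, a 1.1-fold lower number from compound 3 to compound 4 (0.03 log units; within the scatter), is as flat as the earlier one, and the two cores agree on this change: the same change on two cores in this assay, a 1.0-fold higher number (0.01 log units; within the scatter) from compound 1 to compound 2 and a 1.1-fold lower number (0.03 log units; within the scatter) from compound 3 to compound 4, 1.1-fold (0.03 log units) apart, within the scatter of two such steps. Within this series, then, bromo in place of chloro on an aromatic carbon carries from the core of compound 1 to the core of compound 3 with no difference that these numbers can detect. This rests on a single pair of groups at one place on two cores, and since both steps are flat, it does not show whether a change that really moves the number would carry across in the same way, nor why this one leaves the number where it is.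

The compounds shown hold only chloro or bromo on that aromatic ring, so it remains open how a methoxy group, an amine or a carboxylic acid would behave at the same place. Also open, from the compounds shown here alone, is whether the flat step would hold at another place on the ring or on a third core.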